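Compound 1 to compound 4: fluoro for trifluoromethyl

This account rests on a few compounds, and the source may have more. Where it says the series, first, only, none or still open, it means among the compounds named here.

Of the compounds shown here, three have so far been read in an ADME assay on HEK293 cells (Homo sapiens) for cytotoxicity, read by resazurin assay, with a stated time of 48 h; a higher number here means that more compound is tolerated, a lower number that less compound is tolerated. Compound 1 `O=S(=O)(Nc1ccc2oc(-c3ccccc3)nc2c1)c1cccc(C(F)(F)F)c1` gives only a limit, > 100000 nM. Compound 3 `O=S(=O)(Nc1ccc(-c2nc3ccccc3o2)cc1)c1ccccc1Cl` likewise gives only a limit, > 100000 nM. Within the data shown here, compound 2 `O=S(=O)(Nc1ccc(-c2nc3ccccc3o2)cc1)c1ccc(Cl)c(C(F)(F)F)c1` is the one compound with a number, 69000 nM. Compound 1 therefore stands at the limit of > 100000 nM in this assay, at which 2 of the 3 values shown sit.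

Among the measured compounds shown here, no two measured compounds differ in a single place, so the series offers no measured step to lean on. Compound 4 `O=S(=O)(Nc1ccc2oc(-c3ccccc3)nc2c1)c1cccc(F)c1` keeps the core of compound 1 and carries one change: fluoro in place of trifluoromethyl on an aromatic carbon. In words, this is fluoro in place of trifluoromethyl on an aromatic carbon, meta to a large group.

The expectation starts from compound 1 and its limit of > 100000 nM. The change is not expected to move this assay beyond the usual scatter in either direction. The expected step is a number no higher from compound 1 to compound 4 (the limit leaves the size open). A reading of compound 4 as a limit again is the more likely outcome. For compound 4 the estimated value is 100000 nM, with an expected range of 50000 nM to 150000 nM.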

Compound 4, half-maximal cytotoxic concentration: 68000 nM
Compound 4: the middle estimate sits 1.5-fold (0.17 log units) above what was measured; low and high end bracket the measured number.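

In this assay, fluoro in place of trifluoromethyl on an aromatic carbon, meta to a large group, gives the series its first step between compounds that differ in one place (an at least 1.4-fold lower number from compound 1 to compound 4 (0.16 log units; that floor lies within the scatter)). Compound 1 gives only a limit (> 100000 nM), so the real size of this step cannot be read from the floor: (the limit of > 100000 nM in this assay, at which 2 of the 4 values shown sit). What compound 4 adds is a number on the core of compound 1, so further changes at this position can be read as steps from a measured value and not from a limit, while the floor itself, lying within the scatter, does not show that this position is sensitive to the exchange.

As far as these compounds go, it remains open whether this position responds to groups other than these two, such as a methoxy, a nitrile, an amine or a carboxylic acid on the same carbon. From the compounds shown here alone, it also remains open whether the same exchange of trifluoromethyl for fluoro would read alike on the core of compound 2.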